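The source may hold more compounds than are shown below. What is called first, only, known or untested is meant among the compounds shown, and "the series" means these compounds.

Measured in a functional assay on NCI-H1975 cells (Homo sapiens) for antiproliferative activity; a lower number here means a stronger inhibitor, a higher number a weaker inhibitor:
- compound 1 `CC(=O)N1CCc2c(C)c3c(n2-c2ccc(C(N)=O)c(c2)N[C@@H](C)[C@H](C)C1)CC(C)(C)CC3=O`: 15 nM
- compound 2 `Cc1c2c(n3c1CCCN(C(=O)CN)[C@@H](C)[C@H](C)Nc1cc-3ccc1C(N)=O)CC(C)(C)CC2=O`: 380 nM

Of these two, compound 1 has the lower number, and the gap up to compound 2 lies beyond the scatter. Compound 3 `Cc1c2c(n3c1CCN(C(=O)C1(N)CCCC1)C[C@@H](C)[C@H](C)Nc1cc-3ccc1C(N)=O)CC(C)(C)CC2=O` keeps the core of compound 1 but carries 1-aminocyclopentyl in place of methyl on a carbonyl carbon. Within the data shown here, no measured step isolates this change, so the expectation is loose: a rise beyond the scatter in this assay, to a weaker number, with compound 2 at 380 nM as the only other reference. The expected change is a 6.0-fold higher number from compound 1 to compound 3 (0.78 log units; beyond the scatter). The estimate for compound 3 is 90 nM, with an expected range of 25 nM to 350 nM.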

Compound 3, half-maximal inhibitory concentration: 26 nM
Beside the measured number, compound 3's estimate is 3.5-fold (0.54 log units) above it, and the stated range covers the measured number.
By their numbers in this assay, from the lowest: compounds 1 and 3 (each within the scatter of the next); then compound 2.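

In this assay the change from methyl to 1-aminocyclopentyl on a carbonyl carbon gives a 1.7-fold higher number from compound 1 to compound 3 (0.24 log units; within the scatter) and so stays within the scatter. Among these compounds, this position, on a carbonyl carbon whose other neighbours are an amide-type nitrogen in a ring, therefore accepts a group bearing a five-membered ring and an amine with no step that the assay can resolve. Nothing in the data explains this tolerance. The compounds shown leave open how cyclopentyl without the amine, or a carboxylic acid in the same place, would compare.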